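Amide cap exchange on the shared core: benzoyl analogue

This account rests on a few compounds, and the source may have more. Where it says the series, first, only, none or still open, it means among the compounds named here.

Compound 1 `COc1cc(/C=C/C(=O)c2cccc(NC(=O)c3cc(Cl)cc(Cl)c3)c2)ccc1O` stands level with compound 3 `COc1cc(/C=C/C(=O)c2cccc(NC(=O)C(C)C)c2)ccc1O`, the two together the lowest of three numbers in a functional assay on HUVEC cells (Homo sapiens) for inhibition, tested at 5 ug/mL; a lower number here means a weaker effect, a higher number a stronger effect of the compound at the concentration tested: compound 1 gives 51% and compound 3 gives 51%, while compound 2 `COc1cc(/C=C/C(=O)c2cccc(NC(=O)c3ccco3)c2)ccc1O` gives 82%. Compound 4 `COc1cc(/C=C/C(=O)c2cccc(NC(=O)c3ccccc3)c2)ccc1O` differs from compound 1 by phenyl in place of 3,5-dichlorophenyl on a carbonyl carbon. Going by the values given here, the steps that bear on this are a number 31 percentage points higher from compound 1 to compound 2 (beyond the scatter) and no change at the digits printed from compound 1 to compound 3 (within the scatter), so an exchange at this carbonyl carbon has given both a large rise and no change; no measured step swaps one carbon-only ring for another. A step of a number 9 percentage points higher from compound 1 to compound 4 (within the scatter) is expected, its size uncertain. For compound 4 the estimate is 60%, within 45% to 78%.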

Compound 4, a percentage reported as inhibition, at one concentration (the size of the read-out at that concentration, not a potency): 48%
The estimate for compound 4 lay 12 percentage points above the measured number; low and high end bracket the measured number.
By their numbers in this assay, from the lowest: compounds 4, 1 and 3 (each within the scatter of the next); then compound 2.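

In this assay, going by these compounds alone, the first exchange of one carbon-only ring for another on this carbonyl carbon gives a number 3 percentage points lower from compound 1 to compound 4 (within the scatter), so the two chlorines of 3,5-dichlorophenyl make no difference that can be read here. Phenyl and isopropyl also cannot be told apart, with a number 3 percentage points lower from compound 3 to compound 4 (within the scatter), whereas a number 34 percentage points lower from compound 2 to compound 4 (beyond the scatter) leaves furan-2-yl alone apart from the other three caps. Nothing available explains why furan-2-yl stands apart. 

Open, going by these compounds, is whether the higher number belongs to furan-2-yl alone or extends to other ring caps on this carbonyl carbon, such as thiophen-2-yl or pyridin-3-yl.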